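Working notes: replacing a group on compound 2

A few compounds are considered here, and "the series" means these few. Any claim that something is new, unique, unknown or untested is made for them only; others in the source may bear on it.

- compound 1 `CN(C)c1ccc(Nc2c(NCCCCCC(=O)NO)c(=O)c2=O)cc1`: 12000000 nM
- compound 2 `C[C@H](CCCCC(=O)NO)Nc1c(Nc2ccc(N(C)C)cc2)c(=O)c1=O`: 80000000 nM
- compound 3 `C[C@@H](CCCCC(=O)NO)Nc1c(Nc2ccc(N(C)C)cc2)c(=O)c1=O`: 89000000 nM

In a physicochemical assay for solubility, read by HPLC, in phosphate buffer, with a stated time of 24 h, at pH 7.4, tested at 100 uM (a lower number here means a less soluble compound, a higher number a more soluble compound), compound 2 gives 80000000 nM and belongs to the top pair of the three numbers. The gap within that pair is a 1.1-fold higher number from compound 2 to compound 3 (0.05 log units; within the scatter), and it goes with the fact that compounds 2 and 3 differ only in the configuration as drawn. The chain methyl accounts for the larger measured steps, a 6.7-fold higher number from compound 1 to compound 2 (0.82 log units; beyond the scatter) and a 7.4-fold higher number from compound 1 to compound 3 (0.87 log units; beyond the scatter).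

Compound 4 `C[C@H](CCCCC(=O)NO)Nc1c(Nc2ccc(OC(F)(F)F)cc2)c(=O)c1=O` keeps the chain of compound 2 and carries trifluoromethoxy in place of dimethylamino on an aromatic carbon. Among the measured compounds shown here, no measured step touches this place, so the methyl steps offer only a scale, and a wide range is needed. Compound 2, at 80000000 nM, leaves little room upward in this assay, so a step of similar size towards a lower number is expected. The estimated step is a 4.0-fold lower number from compound 2 to compound 4 (0.60 log units; beyond the scatter). For compound 4 the expected value is 20000000 nM, with an estimated range of 5000000 nM to 60000000 nM.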

Compound 4, solubility: 27000000 nM
The estimate for compound 4 lay 1.4-fold (0.13 log units) below the measured number, and the stated range covers the measured number.
By their numbers in this assay, from the lowest: compound 1; then compound 4; then compounds 2 and 3 (each within the scatter of the next).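

The earlier compounds shown here vary only the chain, while compound 4 keeps the chain of compound 2 and shows that the aromatic carbon para to a large group also moves the number in this assay: the exchange of dimethylamino for trifluoromethoxy gives a 3.0-fold lower number from compound 2 to compound 4 (0.47 log units; beyond the scatter). This step runs in the opposite direction to the chain methyl step, a 6.7-fold higher number from compound 1 to compound 2 (0.82 log units; beyond the scatter), and both are modest in size. Nothing measured here accounts for the fall in the number with this exchange.

Going by these compounds, only dimethylamino and trifluoromethoxy appear at this aromatic carbon, so the two groups' separate contributions stay open, as does whether the step holds on the chains of compound 1 and compound 3. A plain hydrogen, a carboxylic acid or a morpholine at the same carbon would give further points for comparison.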